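The source may hold more compounds than are shown below. What is called first, only, known or untested is meant among the compounds shown, and "the series" means these compounds.

The three measured compounds share one core and differ only in the ring on the sulfonyl sulfur or in its substituent. Compound 1 `O=C(Nc1ccc(Cl)cc1)NS(=O)(=O)c1ccc(Cl)s1` carries a 5-chlorothiophen-2-yl group there, and in a functional assay on the whole organism (6C3HED cells, Mus musculus) for inhibition, at a dose of 300 mg/kg by the oral route (on this read-out lower numbers stand for less inhibition and higher numbers for more inhibition at the one dose given (going by the name of the read-out)), compound 1 gives 89%. Compound 2 `CCOc1ccc(S(=O)(=O)NC(=O)Nc2ccc(Cl)cc2)s1` gives 96%, and compound 3 `CCCOc1ccc(S(=O)(=O)NC(=O)Nc2ccc(Cl)cc2)s1` gives 63%. Among these three numbers compound 1 stands second highest: the step of a number 7 percentage points higher from compound 1 to compound 2 (within the scatter) lies within the scatter, whereas the step of a number 26 percentage points lower from compound 1 to compound 3 (beyond the scatter) lies beyond it, as does the step of a number 33 percentage points lower from compound 2 to compound 3 (beyond the scatter).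

Compound 4 `CCc1ccc(S(=O)(=O)NC(=O)Nc2ccc(Cl)cc2)o1` has not yet been measured. Its change from compound 1 is 5-ethylfuran-2-yl in place of 5-chlorothiophen-2-yl on a sulfonyl sulfur. For the measured compounds named here, no measured step exchanges the ring itself, so the only guidance comes from the ring substituent: the step of a number 7 percentage points higher from compound 1 to compound 2 (within the scatter) stayed within the scatter, while the steps of a number 26 percentage points lower from compound 1 to compound 3 (beyond the scatter) and a number 33 percentage points lower from compound 2 to compound 3 (beyond the scatter) went downward. An ethyl group is closer in length to ethoxy than to propoxy, and the exchange of the ring adds an uncertainty whose direction the data do not settle. The step of a number 11 percentage points lower from compound 1 to compound 4 (beyond the scatter) is therefore expected to be small and downward, and compound 4 is estimated to give 78%, within a range from 50% to 96%.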

Compound 4, a percentage reported as inhibition, in the whole organism at one dose (the size of the read-out at that dose, not a potency): 80%
Beside the measured number, compound 4's estimate is 2 percentage points below it, and the stated range covers the measured number.
By their numbers in this assay, from the lowest: compound 3; then compounds 4, 1 and 2 (each within the scatter of the next, the first and the last beyond it).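

In this assay, the step of a number 9 percentage points lower from compound 1 to compound 4 (within the scatter) is the first one shown in which the ring on the sulfonyl sulfur itself changes, and it stays within the scatter even though the ring hetero atom and the ring substituent change together. At this place, then, 5-ethylfuran-2-yl can stand in for 5-chlorothiophen-2-yl without a change in the read-out that can be told from scatter, although the entering group has more heavy atoms and the same counts of hydrogen-bond donors and acceptors. The compounds shown offer no measurement that would explain this result.

For the compounds shown here, what remains open is how the single step divides between the ring and its substituent, which a 5-chlorofuran-2-yl or a 5-ethylthiophen-2-yl group on the same core would help to separate. As far as these compounds go, it is also open whether a longer chain on the furan ring, such as propyl or butyl, would bring a downward step like a number 33 percentage points lower from compound 2 to compound 3 (beyond the scatter), seen with the alkoxy groups, or whether that step belongs to the ethoxy and propoxy pair alone.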